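This account rests on a few compounds, and the source may have more. Where it says the series, first, only, none or still open, it means among the compounds named here.

Measured in a functional assay on HepG2 cells (Homo sapiens) for antiproliferative activity, read by MTT assay, with a stated time of 48 h; a higher number here means a weaker inhibitor, a lower number a stronger inhibitor:
- compound 1 `COc1ccc(N(C)c2ccnc(Cl)n2)cc1OCC[Se]C#N`: 1670 nM
- compound 2 `COc1ccc(N(C)c2ccnc(Cl)n2)cc1OCCC[Se]C#N`: 5150 nM
- compound 3 `COc1ccc(N(C)c2cc(C)nc(C)n2)cc1`: 824 nM

Of these three, compound 3 has the lowest number in this assay, so it is the strongest inhibitor so far. Compound 4 `COc1ccc(N(C)c2cc(C)nc(C)n2)cc1F` differs from compound 3 by fluoro in place of hydrogen on an aromatic carbon, ortho to a methoxy group. Among the compounds with values here, no measured step makes this kind of change. The only one, a 3.1-fold higher number from compound 1 to compound 2 (0.49 log units; beyond the scatter), is a modest step at a saturated chain carbon, so it says little here. A small change is therefore expected, with no direction favoured, and the estimated step of a 1.0-fold lower number from compound 3 to compound 4 (0.01 log units; within the scatter) should stay within the scatter. For compound 4 the expected value is 800 nM, with an estimated range from 300 nM to 2200 nM.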

Compound 4, half-maximal inhibitory concentration: 2060 nM
Beside the measured number, compound 4's estimate is 2.6-fold (0.41 log units) below it, and the stated range covers the measured number.
By their numbers in this assay, from the lowest: compound 3; then compounds 1 and 4 (each within the scatter of the next); then compound 2.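

In this assay, fluoro in place of hydrogen, ortho to a methoxy group, gives a 2.5-fold higher number from compound 3 to compound 4 (0.40 log units; beyond the scatter), so even this one-atom change on the aromatic ring weakens the compound beyond the scatter. Within the data shown here, the only earlier step lay on a saturated chain carbon, which gave no reading of this aromatic position. No measured evidence here explains the loss.

As far as these compounds go, whether the loss is particular to fluoro remains open, since chloro, methyl or hydroxyl on this carbon could behave differently. From the compounds shown here alone, it is also open whether fluoro would have a similar effect on the core of compound 1.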